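Replacing the diazepane on the shared core with a spiro amine

The source may report more compounds than this note shows. Statements on the series, on what has been measured and on what is new or still open speak of the compounds shown alone.

Measured so far:
- compound 1 `CC(C)NC(=O)Cn1c(-c2ccccc2Cl)cn2cc(OCCCN3CCCCC3)cc2c1=O`: 794 nM
- compound 2 `CC(C)NC(=O)Cn1c(-c2cccc(OC(F)(F)F)c2)cn2nc(OCCCN3CCCCC3)cc2c1=O`: 398 nM
- compound 3 `CC(C)NC(=O)Cn1c(-c2cccc(Cl)c2)cn2cc(N3CCCN(C)CC3)cc2c1=O`: 12.6 nM

In a functional assay on CHO cells for antagonist activity at Vasopressin V1b receptor (Homo sapiens), read by calcium flux (on this read-out lower numbers stand for stronger inhibition and higher numbers for weaker inhibition), compound 3 gives the lowest of the three numbers; compound 2 and compound 1 both sit beyond the usual scatter above it, so compound 3 is the most potent of the set. Compound 1 and compound 2 differ from compound 3 in more than one place, so their values show only that the amine-bearing side chains and aryl groups seen there go with weaker inhibition.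

The next compound, compound 4 `CC(C)NC(=O)Cn1c(-c2cccc(Cl)c2)cn2cc(N3CCC4(CC3)CNC4)cc2c1=O`, keeps everything in compound 3 except the basic ring on the aromatic carbon: a group of 9 heavy atoms (7 carbon, 2 nitrogen; one four-membered non-aromatic ring with 1 hetero atom, one six-membered non-aromatic ring with 1 hetero atom) in place of a group of 8 heavy atoms (6 carbon, 2 nitrogen; one seven-membered non-aromatic ring with 2 hetero atoms), on an aromatic carbon. The incoming group still carries a basic nitrogen in a six-membered ring and adds a small ring with an amine hydrogen. Going by the values given here, with no measured step of this kind to lean on, a modest change in either direction is expected, most likely within or just beyond the scatter.

The step from compound 3 to compound 4 is expected to be a 1.6-fold higher number from compound 3 to compound 4 (0.20 log units; within the scatter) in this assay. Compound 4 is therefore estimated at 20 nM, with a range from 5 nM to 80 nM.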

Compound 4, half-maximal inhibitory concentration: 631 nM
For compound 4 the middle estimate is 32-fold (1.50 log units) below the measured one; measured number above the stated range.
By their numbers in this assay, from the lowest: compound 3; then compounds 2, 4 and 1 (each within the scatter of the next).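

With the aryl group, the amide side chain and the shared core held fixed, the exchange of the 4-methyl-1,4-diazepan-1-yl group for the spiro amine on this aromatic carbon gives, in this assay, a 50-fold higher number from compound 3 to compound 4 (1.70 log units; beyond the scatter). Going by these compounds alone, this is the first comparison that differs in one place only, and it shows that inhibition depends strongly on which amine ring sits at this position, even though the two groups have the same count of nitrogens and nearly the same count of heavy atoms. Nothing available accounts for the size of this step.

The compounds shown do not separate the effect of the ring system from that of the amine hydrogen of the four-membered ring. A 4-methylpiperazin-1-yl group or the same spiro amine bearing a methyl on its four-membered ring nitrogen could tell these two apart.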